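The source may report more compounds than this note shows. Statements on the series, on what has been measured and on what is new or still open speak of the compounds shown alone.

Measured in a physicochemical assay for solubility, in phosphate buffer, measured as kinetic solubility, with a stated time of 18 h, at pH 7.4; a lower number here means a less soluble compound, a higher number a more soluble compound:
compound 1 `C/C=C/C(=O)Nc1cccc(-c2nc3ccccc3s2)c1` — 110 nM
compound 2 `CC(Cl)C(=O)Nc1cccc(-c2nc3ccccc3s2)c1` — 830 nM
compound 3 `O=C(Nc1cccc(-c2nc3ccccc3s2)c1)c1cnccc1Cl` — 320 nM

In this assay compound 3 holds the second highest of the three numbers; its nearest neighbour is compound 2 (a 2.6-fold lower number from compound 2 to compound 3 (0.41 log units; beyond the scatter)), its furthest compound 1 (a 2.9-fold higher number from compound 1 to compound 3 (0.46 log units; beyond the scatter)). Compound 4 `O=C(Nc1cccc(-c2nc3ccccc3s2)c1)c1ccnc(Cl)c1` is not yet measured. It differs from compound 3 in one place: 2-chloropyridin-4-yl in place of 4-chloropyridin-3-yl on a carbonyl carbon; the two have the same atoms, joined differently. Among the compounds with values here, no measured step exchanges one chloropyridinyl for another; the steps at the carbonyl carbon (a 7.5-fold higher number from compound 1 to compound 2 (0.88 log units; beyond the scatter), a 2.9-fold higher number from compound 1 to compound 3 (0.46 log units; beyond the scatter), a 2.6-fold lower number from compound 2 to compound 3 (0.41 log units; beyond the scatter)) all swap groups of different kind and were modest. A rearrangement within the same group is expected to give no step beyond the scatter, in no settled direction. Compound 4 is therefore estimated at 320 nM, with a range of 130 nM to 800 nM. The expected step is no change at the digits printed from compound 3 to compound 4 (within the scatter).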

Compound 4, solubility: 740 nM
For compound 4 the middle estimate is 2.3-fold (0.36 log units) below the measured one, and the stated range covers the measured number.
By their numbers in this assay, from the lowest: compound 1; then compound 3; then compounds 4 and 2 (each within the scatter of the next).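

In this assay the exchange of 4-chloropyridin-3-yl for its isomer on the carbonyl carbon is itself a step beyond the scatter (a 2.3-fold higher number from compound 3 to compound 4 (0.36 log units; beyond the scatter)), so rearrangement alone moves the number at this position. The 2-chloropyridin-4-yl group is not separated from 1-chloroethyl (a 1.1-fold lower number from compound 2 to compound 4 (0.05 log units; within the scatter)), while it stands clear of prop-1-en-1-yl (a 6.7-fold higher number from compound 1 to compound 4 (0.83 log units; beyond the scatter)). Nothing available explains the step between the isomers.

As far as these compounds go, whether the placement of the chlorine or of the ring nitrogen carries this step remains open. Also open, from the compounds shown here alone, is how a pyridinyl without chlorine, or one bearing an amine, would compare.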